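This account rests on a few compounds, and the source may have more. Where it says the series, first, only, none or still open, it means among the compounds named here.

Of the compounds shown here, three have been measured in a functional assay on CHO cells for antagonist activity at sphingosine 1-phosphate receptor 2 (Homo sapiens), read by calcium flux; a higher number here means a weaker inhibitor, a lower number a stronger inhibitor. Compound 1 `O=C(O)Cn1nc(CC(=O)Nc2ccc(OC(F)(F)F)c(Cl)c2)c2ccccc2c1=O` gives 389 nM, compound 2 `O=C(O)Cn1nc(Cc2nc3cc(Cl)c(OCC(F)F)cc3[nH]2)c2ccccc2c1=O` gives 12 nM, and compound 3 `O=C(O)Cc1nn(Cc2cn3cc(OCC4CC4)c(Cl)cc3n2)c2ccccc2c1=O` gives 20 nM. Compound 2 has the lowest number of the three. Its nearest neighbour is compound 3, whose value lies within the usual scatter of repeated measurements, so the two cannot be told apart on this evidence. Compound 1 stands far higher, well beyond that scatter, and is the only one of the three whose number clearly differs from that of compound 2.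

Compound 4 `CCOc1cc2[nH]c(Cc3nn(CC(=O)O)c(=O)c4ccccc34)nc2cc1Cl` has not yet been measured. It differs from compound 2 in one place: methyl in place of difluoromethyl on a saturated chain carbon bound to an oxygen on an aromatic ring. Everything else in the molecule stays the same.

Among the measured compounds shown here, no pair of measured compounds differs in only one place, so there is no measured step of this kind to lean on. With the values of compound 2 and compound 3 as the nearest reference points, the expected outcome is a small step, if any, leaning slightly toward a higher number. The expected step is a 1.7-fold higher number from compound 2 to compound 4 (0.22 log units; within the scatter), a change that would not clearly exceed the scatter. Compound 4 is therefore expected to give about 20 nM in this assay, most likely between 8 nM and 50 nM.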

Compound 4, half-maximal inhibitory concentration in the sphingosine 1-phosphate receptor 2 assay: 17 nM
The estimate for compound 4 lay 1.2-fold (0.07 log units) above the measured number; the measured number falls inside the stated range.
By their numbers in the sphingosine 1-phosphate receptor 2 assay, from the lowest: compounds 2, 4 and 3 (each within the scatter of the next); then compound 1.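

Among the compounds shown here, this is the first pair that differs in only one place, so the effect of that place can be read directly. In the sphingosine 1-phosphate receptor 2 assay, going from 2,2-difluoroethoxy to ethoxy gives a 1.4-fold higher number from compound 2 to compound 4 (0.15 log units; within the scatter) and so leaves the two compounds indistinguishable: on this evidence, the two fluorines can be replaced by hydrogens at this position without a measurable loss of inhibition. In a physicochemical assay for lipophilicity, at pH 7.4 (on this read-out higher numbers stand for higher lipophilicity and lower numbers for lower lipophilicity), compound 2 gives 1.97 and compound 4 gives 1.8, values that also lie within the scatter of each other, so the change does not separate the two compounds on this read-out either, and nothing measured here explains why neither number moves clearly.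

This single pair covers only two closely related chains on one shared core, so it cannot show how far the position would accept a different group. On these data alone, a 2,2,2-trifluoroethoxy group, a longer chain or a chain ending in an amine could each behave differently, and whether any of them would keep the inhibition seen here remains open.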